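This account rests on a few compounds, and the source may have more. Where it says the series, first, only, none or still open, it means among the compounds named here.

Going by the values given here, in a functional assay on MCF7 cells (Homo sapiens) for cytotoxicity, read by MTT assay, with a stated time of 96 h (a lower number here means a stronger inhibitor, a higher number a weaker inhibitor), compound 2 `COc1cc(C(=O)c2cn(-c3cccc(N)c3)cc2-c2ccc([N+](=O)[O-])cc2)cc(OC)c1OC` gives 110 nM, the higher of the two numbers so far, while compound 1 `COc1cc(C(=O)c2cn(-c3cccc(N)c3)cc2-c2ccccc2Cl)cc(OC)c1OC` gives 40 nM. Compound 3 `COc1cc(C(=O)c2cn(-c3ccc(F)cc3)cc2-c2ccc([N+](=O)[O-])cc2)cc(OC)c1OC` alters a different part of compound 2: 4-fluorophenyl in place of 3-aminophenyl on an aromatic nitrogen, with 4-fluorophenyl in place of 3-aminophenyl on an aromatic nitrogen. Among the compounds with values here, the only measured step, a 2.8-fold higher number from compound 1 to compound 2 (0.44 log units; beyond the scatter), changes another group, so it offers a yardstick of size and no direct guide. Within the data shown here, a similarly modest move toward a weaker number is expected, a 2.3-fold higher number from compound 2 to compound 3 (0.36 log units; beyond the scatter), though no measurement yet supports that direction. For compound 3, the estimated value is 250 nM, within a range of 60 nM to 1000 nM.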

Compound 3, half-maximal inhibitory concentration: 240 nM
Beside the measured number, compound 3's estimate is 1.0-fold (0.02 log units) above it; the measured number falls inside the stated range.
By their numbers in this assay, from the lowest: compound 1; then compound 2; then compound 3.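

In this assay, putting 4-fluorophenyl in place of 3-aminophenyl on the aromatic nitrogen gives a 2.2-fold higher number from compound 2 to compound 3 (0.34 log units; beyond the scatter). The group on this nitrogen therefore matters too, not only the group changed in the earlier step on an aromatic carbon. No available evidence explains the shift. The swap removes the amine and adds fluorine at once, so the effect of each remains unseparated. A plain phenyl group or a 3-fluorophenyl group on this nitrogen would help tell them apart.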